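This account rests on a few compounds, and the source may have more. Where it says the series, first, only, none or still open, it means among the compounds named here.

Compound 1 `CN1CCN(c2ccc3nc(-c4ccc(-c5ccccc5)s4)c(-c4ccncc4)n3n2)CC1` is one of two compounds tested in an assay on Sf9 cells for inhibition of receptor-interacting serine/threonine-protein kinase 3 (Homo sapiens), read by luminescence and 33P incorporation, with a stated time of 30 min, in the presence of a further agent that is not named here; on this read-out higher numbers stand for weaker inhibition and lower numbers for stronger inhibition. Compound 1 reached only the limit of the test, > 10000 nM, so it carries no number of its own and sits at the limit of > 10000 nM in this assay, at which 1 of the 2 values shown sits. Compound 2 `CN1CCN(c2ccc3nc(-c4cccc(-c5ccccc5)c4)c(-c4ccncc4)n3n2)CC1` gave 450 nM in this assay. Compound 3 `CN1CCN(c2ccc3nc(-c4cccc5ccccc45)c(-c4ccncc4)n3n2)CC1` differs from compound 1 by naphthalen-1-yl in place of 5-phenylthiophen-2-yl on an aromatic carbon. Among the measured compounds shown here, no measured pair shares this exact change, so the size of the step is open. Given that compound 2 gave 450 nM, compound 3 is expected to come in at 1500 nM, between 200 nM and 10000 nM. The step this estimate implies, an at least 6.6-fold lower number from compound 1 to compound 3 (0.82 log units; beyond the scatter), is expected to run toward stronger inhibition.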

Compound 3, half-maximal inhibitory concentration: 880 nM
Compound 3: the middle estimate sits 1.7-fold (0.23 log units) above what was measured; the measured number falls inside the stated range.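

On this aromatic carbon of the shared core, naphthalen-1-yl in place of 5-phenylthiophen-2-yl gives an at least 11-fold lower number from compound 1 to compound 3 (1.05 log units; beyond the scatter). So a group made of two six-membered aromatic rings of carbon only, with no sulfur, still allows measurable inhibition at this place. The true size of the step stays unknown, since compound 1 sits at a limit of the test: the limit of > 10000 nM in this assay, at which 1 of the 3 values shown sits.

From the compounds shown here alone, it remains open whether both carbon rings are needed, which a single phenyl at this carbon could test. Also open, going by these compounds, is whether a ring holding nitrogen, such as morpholine, would serve here.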